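From Thiazole to Methylthiophene on the Amide Side Chain

The compounds below may be only part of what the source reports. "The series", "measured", "known", "first", "only" and "open" are said of these compounds alone.

Three compounds share one core and differ only in the aromatic ring carried on the saturated chain carbon bound to the amide-type nitrogen. In an assay on HEK293 cells for agonist activity at transient receptor potential cation channel subfamily M member 8 (Homo sapiens), read by fluorescence and calcium flux, with a stated time of 15 min (on this read-out lower numbers stand for an effect already at smaller amounts and higher numbers for an effect only at larger amounts of compound), compound 1 `CCN(Cc1ccco1)C(=O)COc1ccc(C)cc1` gives 489 nM, compound 2 `CCN(Cc1ccsc1)C(=O)COc1ccc(C)cc1` gives 88 nM, and compound 3 `CCN(Cc1nccs1)C(=O)COc1ccc(C)cc1` gives 3060 nM. Compound 3 thus stands highest of the three: the step of a 6.3-fold higher number from compound 1 to compound 3 (0.80 log units; beyond the scatter) and the step of a 35-fold higher number from compound 2 to compound 3 (1.54 log units; beyond the scatter) both run upward to it. Compound 4 `CCN(Cc1ccc(C)s1)C(=O)COc1ccc(C)cc1` is not yet measured. It differs from compound 3 by 5-methylthiophen-2-yl in place of 1,3-thiazol-2-yl on a saturated chain carbon bound to an amide-type nitrogen. The step that bears most directly on this change is a 35-fold higher number from compound 2 to compound 3 (1.54 log units; beyond the scatter), which runs from thiophen-3-yl to 1,3-thiazol-2-yl; the move at hand reverses that direction, toward a 5-methylthiophen-2-yl ring. The step of a 5.6-fold lower number from compound 1 to compound 2 (0.74 log units; beyond the scatter) also shows thiophen-3-yl giving the lowest number seen. Compound 4 is therefore expected to give a markedly lower number than compound 3 in this assay, a step of about a 20-fold lower number from compound 3 to compound 4 (1.31 log units; beyond the scatter). The estimate for compound 4 is 150 nM, with a range from 40 nM to 600 nM.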

Compound 4, half-maximal effective concentration: 178 nM
For compound 4 the middle estimate is 1.2-fold (0.07 log units) below the measured one; measured number inside the range.
By their numbers in this assay, from the lowest: compound 2; then compound 4; then compound 1; then compound 3.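

In this assay, the step of a 17-fold lower number from compound 3 to compound 4 (1.24 log units; beyond the scatter) shows that the low numbers at this position are not confined to thiophen-3-yl, since a second thiophene ring, 5-methylthiophen-2-yl, also lies far below 1,3-thiazol-2-yl. The two thiophene rings are still not equivalent: the step of a 2.0-fold higher number from compound 2 to compound 4 (0.31 log units; beyond the scatter) leaves the new ring above thiophen-3-yl, while the step of a 2.7-fold lower number from compound 1 to compound 4 (0.44 log units; beyond the scatter) puts it below furan-2-yl. Among these four compounds, both thiophene rings give lower numbers than the furan-2-yl and 1,3-thiazol-2-yl rings, and no compound goes against this.

As far as these compounds go, compound 2 and compound 4 differ in both the ring attachment and the methyl group, so a thiophen-2-yl ring without the methyl, or a phenyl ring, remains open here. Nothing available explains these differences.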